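The source may hold more compounds than are shown below. What is called first, only, known or untested is meant among the compounds shown, and "the series" means these compounds.

Measured so far in an assay on isolated protein for inhibition of histone deacetylase 4 (Homo sapiens); on this read-out higher numbers stand for weaker inhibition and lower numbers for stronger inhibition:
compound 1, `CCCNNC(=O)c1cnc(N2CCN(Cc3c[nH]c4ccccc34)CC2)nc1`, only a limit of the assay: > 20000 nM
compound 2, `CCCCCCNNC(=O)c1ccc(-c2ccc(CNC(C)=O)cc2)cc1`, only a limit of the assay: > 20000 nM
compound 3, `CCCNNC(=O)c1cnc(NCc2ccccc2)nc1`, only a limit of the assay: > 20000 nM

None of the three gives a number in this assay; each sits at the limit of > 20000 nM in this assay, at which 3 of the 3 values shown sit. Going by the values given here, compound 2 therefore stands nowhere above or below the others, and no step between measured compounds can be drawn. Compound 4, `CCCNNC(=O)c1ccc(-c2ccc(CNC(C)=O)cc2)cc1`, differs from compound 2 by hydrogen in place of propyl on a saturated chain carbon, three bonds along the chain from an amine nitrogen. With every value resting at the limit, no direction can be read from the data; the step from compound 2 to compound 4 is expected to stay within the scatter, and compound 4 is expected to remain at the limit as well. The estimate for compound 4 is 30000 nM, with a range from 10000 nM to 100000 nM. The step that the limit leaves unreadable from compound 2 to compound 4 is thus expected to be negligible.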

Compound 4, half-maximal inhibitory concentration: 990 nM
Compound 4: middle estimate off by 30-fold (1.48 log units), on the high side; the measured number lies below the stated range.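

In this assay, the change from hexyl to propyl on this chain gives the first number among these compounds, with an at least 20-fold lower number from compound 2 to compound 4 (1.30 log units; beyond the scatter). Compound 2 gives only a limit of the assay, > 20000 nM. The step is therefore a bound on the size of the change, not its full measure: the limit of > 20000 nM in this assay, at which 3 of the 4 values shown sit.

The compounds shown leave open how a butyl or pentyl chain would fall between these two, and whether an ethyl chain would lower the number further. They also leave open whether an amine at the end of the chain would be tolerated.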